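The source may hold more compounds than are shown below. What is called first, only, known or untested is meant among the compounds shown, and "the series" means these compounds.

Measured compounds:
- compound 1, `CCC1=C(O)c2c(oc(-c3ccc(O)cc3)cc2=O)C(CC)(CC)C1=O`, 20.6 uM in a functional assay on KB cells (Homo sapiens) for antiproliferative activity, read by sulforhodamine B assay, with a stated time of 3 days; on this read-out higher numbers stand for an effect only at larger amounts of compound and lower numbers for an effect already at smaller amounts
- compound 2, `CCC1=C(O)c2c(oc(-c3ccc(OC)cc3)cc2=O)C(CC)(CC)C1=O`, 17.7 uM in this assay
- compound 3, `CCC1=C(O)c2c(oc(-c3ccccc3C)cc2=O)C(CC)(CC)C1=O`, 40.9 uM in this assay

Compound 2 gives the lowest of the three numbers in this assay. Its nearest neighbour is compound 1, with a 1.2-fold lower number from compound 1 to compound 2 (0.07 log units; within the scatter), a difference too small to rank the two. Compound 3 lies furthest away, with a 2.3-fold higher number from compound 2 to compound 3 (0.36 log units; beyond the scatter).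

The unmeasured compound 4, `CCC1=C(O)c2c(oc(-c3ccc(O)c(C)c3C)cc2=O)C(CC)(CC)C1=O`, arises from compound 2 by the change (4-hydroxy-2,3-dimethylphenyl in place of 4-methoxyphenyl on an aromatic carbon). For the measured compounds named here, two measured steps bear on it. The step of a 1.2-fold lower number from compound 1 to compound 2 (0.07 log units; within the scatter) shows that exchanging methyl for hydrogen on the aromatic oxygen stays within the scatter, so the return to a free hydroxyl is not expected to matter. The step of a 2.3-fold higher number from compound 2 to compound 3 (0.36 log units; beyond the scatter) shows that a methyl placed on the phenyl ring, as in compound 3, went with a modestly higher number. Compound 4 carries two such methyls together with the hydroxyl, so a modest rise in the number, in the direction seen for compound 3, is expected; the step is estimated as a 1.7-fold higher number from compound 2 to compound 4 (0.23 log units; within the scatter). Compound 4 is therefore expected to give about 30 uM in this assay, within a range from 13 uM to 70 uM.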

Compound 4, concentration for half-maximal effect: 6.5 uM
Beside the measured number, compound 4's estimate is 4.6-fold (0.66 log units) above it, outside the stated range (below it).
By their numbers in this assay, from the lowest: compound 4; then compounds 2, 1 and 3 (each within the scatter of the next, the first and the last beyond it).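

Among the earlier compounds, no change of the group on this aromatic carbon, next to the ring oxygen, had moved the number in this assay downward beyond the scatter, whereas 4-hydroxy-2,3-dimethylphenyl gives a 2.7-fold lower number from compound 2 to compound 4 (0.44 log units; beyond the scatter) and a 3.2-fold lower number from compound 1 to compound 4 (0.50 log units; beyond the scatter) as the first such drops. Methyl on the phenyl ring thus does not push the number one way at this position: compound 3 and compound 4 both carry it, yet they stand at the two ends of the series, with a 6.3-fold lower number from compound 3 to compound 4 (0.80 log units; beyond the scatter) as the widest gap among the four compounds. Nothing measured here accounts for the lower number of compound 4.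

The compounds shown leave open whether the hydroxyl and the two methyls work only in combination, which a 4-hydroxy-3-methylphenyl group would begin to test. They also leave open whether an amine or a carboxylic acid in place of the hydroxyl, or a longer chain such as ethyl in place of a methyl, would shift the number further in either direction.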